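A methoxy group on the carboxyphenyl amide

This account rests on a few compounds, and the source may have more. Where it says the series, first, only, none or still open, it means among the compounds named here.

Measured so far in an ADME assay on microsomes from liver (Homo sapiens) for pharmacokinetics, read by LC-MS, tested at 1 mM; on this read-out higher numbers stand for fast clearance and lower numbers for slow clearance:
- compound 1 `CC(C)(C)C[C@@H]1N[C@@H](C(=O)Nc2ccn(CC(C)(C)O)n2)[C@H](c2cccc(Cl)c2F)[C@@]1(C#N)c1ccc(Cl)cc1F` gives 4.2 mL/min/kg here
- compound 2 `CC(C)(C)C[C@@H]1N[C@@H](C(=O)Nc2ccc(C(=O)O)cc2)[C@H](c2cccc(Cl)c2F)[C@@]1(C#N)c1ccc(Cl)cc1F` gives 4.9 mL/min/kg here

Only these two compounds have been measured, and compound 2, at 4.9 mL/min/kg in this assay, stands level with compound 1 within the scatter. Going by the values given here, both numbers lie close together, and the single measured step, a 1.2-fold higher number from compound 1 to compound 2 (0.07 log units; within the scatter), exchanged the whole group on the amide nitrogen.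

Compound 3 `COc1cc(NC(=O)[C@@H]2N[C@@H](CC(C)(C)C)[C@](C#N)(c3ccc(Cl)cc3F)[C@H]2c2cccc(Cl)c2F)ccc1C(=O)O` keeps the shared core of compound 2 and differs by one change, (methoxy in place of hydrogen on an aromatic carbon). This is methoxy in place of hydrogen on an aromatic carbon, ortho to a carboxy group and meta to a large group, so 4-carboxyphenyl becomes 4-carboxy-3-methoxyphenyl.

Among the compounds with values here, no measured pair tests this change directly, so the evidence is indirect and thin. The larger exchange in a 1.2-fold higher number from compound 1 to compound 2 (0.07 log units; within the scatter) stayed within the scatter, so no shift beyond the scatter is expected here. The expected change is a 1.1-fold higher number from compound 2 to compound 3 (0.05 log units; within the scatter), with no firm direction. The estimate for compound 3 is 5.5 mL/min/kg, with an expected range from 3 mL/min/kg to 10 mL/min/kg.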

Compound 3, clearance: 6.6 mL/min/kg
Estimate against measurement, compound 3: 1.2-fold (0.08 log units) below, within the range that was stated.
By their numbers in this assay, from the lowest: compounds 1, 2 and 3 (each within the scatter of the next).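

In this assay, going by these compounds alone, the step of a 1.3-fold higher number from compound 2 to compound 3 (0.13 log units; within the scatter) gives the first direct reading at this position, showing that methoxy in place of hydrogen on an aromatic carbon, ortho to a carboxy group and meta to a large group, leaves the clearance number within the scatter. The longer comparison, a 1.6-fold higher number from compound 1 to compound 3 (0.20 log units; within the scatter), also stays within the scatter, so even with the methoxy added to the 4-carboxyphenyl group, the exchange on the amide-type nitrogen has not yet moved the read-out measurably in these three compounds. No measured evidence bears on this result.

The compounds shown leave open whether a different group at this same place, such as ethoxy, fluorine or an amine, would carry the clearance number beyond the scatter, or whether this position simply allows such changes. Within the data shown here, they also leave open whether the methoxy would read the same if the carboxy group it accompanies gave way to a primary amide or a tetrazole, since every step so far stays within the scatter.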